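Same Ester Swap, Tried on a Second Core

This account rests on a few compounds, and the source may have more. Where it says the series, first, only, none or still open, it means among the compounds named here.

In a functional assay on the whole organism (strain CD1) for inhibition, with Mus musculus as the target, with stated times of 15 min and 20 min, at a dose of 10 mg/kg by the subcutaneous route (on this read-out higher numbers stand for more inhibition at the one dose given (going by the name of the read-out) and lower numbers for less inhibition), compound 1 `CC(C)CCOC(=O)/C(C#N)=C/c1ccc(O)c(O)c1` gives 27.2%. Compound 2 `N#C/C(=C\c1ccc(O)c(O)c1)C(=O)OC1CCCCC1` differs from it in a single place, (cyclohexyl in place of isopentyl on an oxygen next to a carbonyl group), and in this assay compound 2 gives 55.3%. Within the data shown here, the step of a number 28.1 percentage points higher from compound 1 to compound 2 (beyond the scatter) is the one piece of evidence on what this swap does. Compound 3 `CC(C)CCOC(=O)/C(C#N)=C/c1cc2ccccc2[nH]1` is built on a different core; the difference between the two cores is not broken down here. In this assay compound 3 gives 46.6%; set beside compound 2 this lies within the scatter, while against compound 1 it lies beyond it. Compound 4 `N#C/C(=C\c1cc2ccccc2[nH]1)C(=O)OC1CCCCC1` is not yet measured. It carries the same change that turned compound 1 into compound 2, (cyclohexyl in place of isopentyl on an oxygen next to a carbonyl group), made at a place described in exactly the same words, so the two changes count as the same. Among the measured compounds shown here, a step of a number 23.4 percentage points higher from compound 3 to compound 4 (beyond the scatter) is expected because a number 28.1 percentage points higher from compound 1 to compound 2 (beyond the scatter) was seen once already, though on only one pair of compounds. Compound 4 is thus estimated to give 70%, with a likely range from 50% to 88%.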

Compound 4, a percentage reported as inhibition, in the whole organism at one dose (the size of the read-out at that dose, not a potency): 83.6%
For compound 4 the middle estimate is 13.6 percentage points below the measured one, within the range that was stated.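

In this assay, cyclohexyl in place of isopentyl on an oxygen next to a carbonyl group gives a number 37 percentage points higher from compound 3 to compound 4 (beyond the scatter). The change therefore carries over to the second core, pointing the same way, and its size there cannot be told apart from its size on the first core: the same change on two cores in this assay, a number 28.1 percentage points higher (beyond the scatter) from compound 1 to compound 2 and a number 37 percentage points higher (beyond the scatter) from compound 3 to compound 4, 8.9 percentage points apart, within the scatter of two such steps. This rests on just two pairs of compounds at a single dose, which is not a measure of potency, so it sets no rule for other cores and does not tell what about the cyclohexyl group produces these steps.

The compounds shown place only isopentyl and cyclohexyl on that oxygen, so it remains open how a cyclopentyl ring, a benzyl group or a longer chain would behave there. As far as these compounds go, it is also open whether a group carrying an amine or a carboxylic acid in that place would keep the higher numbers on either core.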